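A few compounds are considered here, and "the series" means these few. Any claim that something is new, unique, unknown or untested is made for them only; others in the source may bear on it.

Compound 1 `CC1CCN(c2cc(C(C)(C)C)ccc2CNC(=O)C(C)c2ccc3c(c2)CCC3)CC1`: 61.7 nM
Compound 2 `CC(C(=O)NCc1cc(C(F)(F)F)nn1-c1cccc(C(F)(F)F)c1)c1ccc2c(c1)CCC2`: 7.5 nM

Both numbers come from an assay on CHO-K1 cells for antagonist activity at transient receptor potential cation channel subfamily V member 1 (Homo sapiens), read by FLIPR; on this read-out higher numbers stand for weaker inhibition and lower numbers for stronger inhibition. Among the two values shown, compound 2 has the lowest; its nearest neighbour is compound 1, whose number is higher by a gap that goes beyond the usual scatter of repeated measurements.

Compound 3 `CC(C(=O)NCc1cc(C(F)(F)F)nn1-c1ccc(C(F)(F)F)cc1)c1ccc2c(c1)CCC2` has not yet been measured in this assay. It differs from compound 2 in one place only: 4-(trifluoromethyl)phenyl in place of 3-(trifluoromethyl)phenyl on an aromatic nitrogen. Going by the values given here, no measured pair shows what a change of this kind does, so there is no direct basis for the size or direction of the step. Without such a basis, the expectation is a step that stays within the scatter, in no set direction. Compound 3 is therefore estimated at 10 nM in this assay, with a range of 3 nM to 40 nM. The expected step, a 1.3-fold higher number from compound 2 to compound 3 (0.12 log units; within the scatter), is small.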

Compound 3, inhibition constant: 51.3 nM
The estimate for compound 3 lay 5.1-fold (0.71 log units) below the measured number; measured number above the stated range.
By their numbers in this assay, from the lowest: compound 2; then compounds 3 and 1 (each within the scatter of the next).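

In this assay, replacing 3-(trifluoromethyl)phenyl with 4-(trifluoromethyl)phenyl on the aromatic nitrogen gives a 6.8-fold higher number from compound 2 to compound 3 (0.84 log units; beyond the scatter). Going by these compounds alone, this is the first measured pair here that differs in one place only, and it shows that this position responds to where the trifluoromethyl group sits on the phenyl ring, even though the group that leaves and the group that enters have the same atoms and the same counts of donors and acceptors. Nothing measured here explains why the number rises with this change.

As far as these compounds go, it remains open whether a plain phenyl ring on that nitrogen would give a higher or a lower number than either compound. From the compounds shown here alone, it is also open whether a chlorine atom, a methoxy group or a nitrile in place of the trifluoromethyl group would respond to the same move in the same way.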